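The source may hold more compounds than are shown below. What is called first, only, known or untested is meant among the compounds shown, and "the series" means these compounds.

Compound 2 `COc1ccc(-c2cc(/C=C/C(=O)c3ccc(N)cc3)[nH]n2)cc1OC` and compound 1 `COc1ccc(-c2cc(/C=C/C(=O)c3ccc(N)cc3)[nH]n2)cc1` share a core and differ at one place: hydrogen in place of methoxy on an aromatic carbon. In a functional assay on M14 cells (Homo sapiens) for cytotoxicity, read by sulforhodamine B assay, with a stated time of 48 h, tested at 100 uM (on this read-out lower numbers stand for a stronger effect and higher numbers for a weaker effect at the one concentration tested), compound 2 gives -90%, while compound 1 gives -71%, and this change made a number 19 percentage points higher from compound 2 to compound 1 (beyond the scatter). Compound 3 `COc1cc(C(=O)/C=C/c2cc(-c3cc(OC)c(OC)c(OC)c3)n[nH]2)cc(OC)c1OC` carries a different core; how its core differs from that of compound 2 is not broken down here. In this assay compound 3 gives -88%. Compound 4 `COc1ccc(-c2cc(/C=C/C(=O)c3cc(OC)c(OC)c(OC)c3)[nH]n2)cc1OC` is not yet measured; it differs from compound 3 by hydrogen in place of methoxy on an aromatic carbon. The surroundings are not identical, as in compound 3 the place is also meta to a methoxy group, so this is the same kind of change rather than the same one. Compound 4 is expected to move by a number 19 percentage points higher from compound 3 to compound 4 (beyond the scatter), resting on the step from compound 2 to compound 1, which was a number 19 percentage points higher from compound 2 to compound 1 (beyond the scatter). Compound 4 is therefore estimated at -69%, within -85% to -50%.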

Compound 4, a percentage reported as activity, at one concentration (the size of the read-out at that concentration, not a potency): -74%
Compound 4: middle estimate off by 5 percentage points, on the high side, and the stated range covers the measured number.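

In this assay, replacing one methoxy group with hydrogen weakened the effect on the second core too, giving a number 14 percentage points higher from compound 3 to compound 4 (beyond the scatter). Set beside the earlier step, the same change moved the read-out in the same direction and by a comparable amount on both cores: the same change on two cores in this assay, a number 19 percentage points higher (beyond the scatter) from compound 2 to compound 1 and a number 14 percentage points higher (beyond the scatter) from compound 3 to compound 4, 5 percentage points apart, within the scatter of two such steps. This supports carrying the change between these two cores, but two pairs cannot show that it would hold on other cores, and they do not explain why the effect weakens.

The compounds shown compare methoxy only with hydrogen at this place, so the effect of a hydroxyl group, a carboxylic acid or a longer chain such as ethoxy remains open. As far as these compounds go, whether the step would persist at other concentrations or in other cell lines also remains open.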